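Does a longer ester side chain change cytotoxicity?

The source may hold more compounds than are shown below. What is called first, only, known or untested is meant among the compounds shown, and "the series" means these compounds.

Compound 1 `CCOC(=O)Cn1c(=O)c(-c2ccc(OC)cc2)cc2c(OC)cc(OC)cc21`: 10000 nM
Compound 2 `COc1ccc(-c2cc3c(OC)cc(OC)cc3n(CC(=O)O)c2=O)cc1`: 10000 nM

Going by the values given here, in a functional assay on A549 cells (Homo sapiens) for cytotoxicity, read by colorimetric assay and MTT assay (on this read-out higher numbers stand for weaker inhibition and lower numbers for stronger inhibition), compound 2 gives 10000 nM, level with compound 1 and the only other measured compound. Compound 3 `COC(=O)CCn1c(=O)c(-c2ccc(OC)cc2)cc2c(OC)cc(OC)cc21` has not been measured yet. It keeps the core of compound 2 and alters only the side chain: (methoxycarbonyl)methyl in place of carboxy on a saturated chain carbon bound to an aromatic nitrogen. In words, (methoxycarbonyl)methyl stands in place of carboxy on a saturated chain carbon bound to an aromatic nitrogen, so carboxymethyl becomes 2-(methoxycarbonyl)ethyl.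

Among the compounds with values here, the one measured step also alters this side chain, with hydrogen replacing ethyl, and it shows no change at the digits printed from compound 1 to compound 2 (within the scatter). Within the data shown here, that single step is thin evidence, and no measured compound carries the 2-(methoxycarbonyl)ethyl group. Even so, no shift beyond the scatter is expected in this assay. The expected change is no change at the digits printed from compound 2 to compound 3 (within the scatter). The estimate for compound 3 is 10000 nM, within an expected range of 5000 nM to 20000 nM.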

Compound 3, half-maximal inhibitory concentration: 10000 nM
Compound 3: middle estimate and measured number agree at the digits printed; the range from low to high includes it.
By their numbers in this assay, from the lowest: compounds 1, 2 and 3 (each within the scatter of the next).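

Read in this assay the swap of carboxymethyl for 2-(methoxycarbonyl)ethyl gives no change at the digits printed from compound 2 to compound 3 (within the scatter) and the swap of ethoxycarbonyl for (methoxycarbonyl)methyl on a saturated chain carbon bound to an aromatic nitrogen gives no change at the digits printed from compound 1 to compound 3 (within the scatter) as well. The earlier pair differed only at the far end of the side chain, whereas compound 3 also carries a longer chain between the aromatic nitrogen and the carbonyl, and its number still matches those of compound 1 and compound 2. Nothing available explains why these side chains read alike.

Going by these compounds, all three compounds sit at one level, so it remains open whether any side chain at this position can move the number. On these data alone, how an amine or an amide at the end of this chain, or a still longer chain, would read in this assay stays unknown here.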